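The source may hold more compounds than are shown below. What is called first, only, known or untested is meant among the compounds shown, and "the series" means these compounds.

Measured so far:
compound 1, `Cc1cn(-c2cc(NC(=O)c3ccc(C)c(Nc4nc(-c5cccnc5)cs4)c3)cc(C(F)(F)F)c2)cn1` — 30 nM
compound 2, `Cc1cn(-c2cc(NC(=O)c3ccc(C)c(Nc4nc(-c5cccnc5)cs4)c3)cc(C(C)C)c2)cn1` — 51 nM
compound 3, `Cc1cn(-c2cc(NC(=O)c3ccc(C)c(Nc4nc(-c5cccnc5)cs4)c3)cc(C(C)(C)C)c2)cn1` — 11 nM

All three share one core and differ only in the substituent on the ring that carries the 4-methyl-1H-imidazol-1-yl group. In a functional assay on KU812 cells (Homo sapiens) for antiproliferative activity (on this read-out higher numbers stand for weaker inhibition and lower numbers for stronger inhibition), compound 3 gives the lowest number of the three: its step from compound 1 is a 2.7-fold lower number from compound 1 to compound 3 (0.44 log units; beyond the scatter) and from compound 2 a 4.6-fold lower number from compound 2 to compound 3 (0.67 log units; beyond the scatter), both beyond the scatter, so compound 3 stands as the most potent of the set. Between the other two, a 1.7-fold higher number from compound 1 to compound 2 (0.23 log units; within the scatter), so no order can be claimed there.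

Compound 4, `Cc1cn(-c2cc(Cl)cc(NC(=O)c3ccc(C)c(Nc4nc(-c5cccnc5)cs4)c3)c2)cn1`, is not yet measured. The change from compound 3 is chloro in place of tert-butyl on an aromatic carbon. Among the compounds with values here, none of the measured steps puts a single halogen in this position, so no step bears on it directly. The nearest bearings are a 4.6-fold lower number from compound 2 to compound 3 (0.67 log units; beyond the scatter) and a 2.7-fold lower number from compound 1 to compound 3 (0.44 log units; beyond the scatter): each shows that replacing tert-butyl by another substituent at this position raised the number by a modest amount. A loss of comparable size is therefore expected here. For compound 4 the estimate in this assay is 35 nM, within 12 nM to 100 nM, an expected step of a 3.2-fold higher number from compound 3 to compound 4 (0.50 log units; beyond the scatter).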

Compound 4, half-maximal inhibitory concentration: 518 nM
Compound 4: the middle estimate sits 15-fold (1.17 log units) below what was measured; the measured number lies above the stated range.
By their numbers in this assay, from the lowest: compound 3; then compounds 1 and 2 (each within the scatter of the next); then compound 4.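

In this assay the chloro compound stands apart from the rest of the series: a 47-fold higher number from compound 3 to compound 4 (1.67 log units; beyond the scatter) and a 10-fold higher number from compound 2 to compound 4 (1.01 log units; beyond the scatter) and a 17-fold higher number from compound 1 to compound 4 (1.24 log units; beyond the scatter). The earlier exchanges of trifluoromethyl, isopropyl and tert-butyl on this aromatic carbon, meta to the 4-methyl-1H-imidazol-1-yl group, moved the number by modest amounts at most, so only compound 4 shows that a change here can cost far more, and its chloro brings one heavy atom where tert-butyl has four. Nothing measured on these compounds accounts for the size of this loss.

The compounds shown leave open whether the loss goes with chlorine itself or with any substituent of a single heavy atom, a question that a fluoro, bromo or methyl group at this position could help settle. Also open, as far as these compounds go, is how groups of another kind would behave here, such as a methoxy, a dimethylamino or a cyclohexyl group, and whether any of them could give a lower number than compound 3.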